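Indolyl for Furanyl on a Cytotoxicity-Silent Scaffold

This account rests on a few compounds, and the source may have more. Where it says the series, first, only, none or still open, it means among the compounds named here.

Compound 2 `CCOC(=O)CCCCCOc1cccc(CN(C(=O)c2ccc(-c3ccoc3)cc2)C(C)C)c1` was tested in an ADME assay on HEK293 cells (Homo sapiens) for cytotoxicity, read by CellTiter-Glo and resazurin assay, with a stated time of 72 h; a lower number here means that less compound is needed, a higher number that more compound is needed for the effect. In this assay compound 2 reaches only the limit > 26000 nM, not a number. Compound 1 `CC(C)N(Cc1cccc(OCCCCCC(=O)O)c1)C(=O)c1ccc(-c2ccc3cc[nH]c3c2)cc1`, which already carries the 1H-indol-6-yl group, likewise stops at the limit > 26000 nM in this assay. Both values rest on (the limit of > 26000 nM in this assay, at which 2 of the 2 values shown sit). Compound 3 `CCOC(=O)CCCCCOc1cccc(CN(C(=O)c2ccc(-c3ccc4cc[nH]c4c3)cc2)C(C)C)c1` differs from compound 2 by 1H-indol-6-yl in place of furan-3-yl on an aromatic carbon. No measured step links the compounds shown, and compound 1 with the same entering group sits at the limit of > 26000 nM in this assay, at which 2 of the 2 values shown sit. The step is therefore expected to be a step that the limit leaves unreadable from compound 2 to compound 3, nothing beyond the scatter. Compound 3 is estimated at 30000 nM, between 15000 nM and 80000 nM, most likely again only a limit.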

Compound 3, half-maximal effective concentration: > 26000 nM
Compound 3 ended at the assay's limit (the forecaster's own chance of this, stated with the estimate: 80%); the middle value lies beyond the limit too.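

Neither step to compound 3, from compound 1 or from compound 2, can be read: the limit of > 26000 nM in this assay, at which 3 of the 3 values shown sit.

On these data alone, whether 1H-indol-6-yl in place of furan-3-yl, or ethyl in place of hydrogen, shifts the result in this assay at all stays open.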